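The compounds below may be only part of what the source reports. "The series", "measured", "known", "first", "only" and "open" are said of these compounds alone.

Measured in a physicochemical assay for solubility, read by HPLC, with a stated time of 24 h; a higher number here means a more soluble compound, a lower number a less soluble compound:
- Compound 1 `CN(CCC#N)C[C@H]1CN(c2ccc(-n3cc(-c4ccccn4)cn3)c(F)c2)C(=O)O1`: 64500 nM
- Compound 2 `CN1CCN(C[C@H]2CN(c3ccc(-n4cc(-c5ccccn5)cn4)c(F)c3)C(=O)O2)CC1`: 1690000 nM
- Compound 3 `COC(=O)CC1CCN(C[C@H]2CN(c3ccc(-n4cc(-c5ccccn5)cn4)c(F)c3)C(=O)O2)CC1`: 92100 nM

Compound 3 sits with compound 1 on these numbers, the measured step being a 1.4-fold higher number from compound 1 to compound 3 (0.15 log units; within the scatter). The third value lies well apart, as shown by an 18-fold lower number from compound 2 to compound 3 (1.26 log units; beyond the scatter) and by a 26-fold higher number from compound 1 to compound 2 (1.42 log units; beyond the scatter).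

Compound 4 `O=C1CCC(=O)N1C[C@H]1CN(c2ccc(-n3cc(-c4ccccn4)cn3)c(F)c2)C(=O)O1` has not yet been measured. It carries 2,5-dioxopyrrolidin-1-yl in place of 4-((methoxycarbonyl)methyl)piperidin-1-yl on a saturated chain carbon bound to a saturated ring carbon.

All three measured steps change the group at this same place, but none involves the entering group, so they offer only indirect guidance. Both large steps involve compound 2, which carries 4-methylpiperazin-1-yl, and nothing measured links the entering group to that result. The closer precedent is a 1.4-fold higher number from compound 1 to compound 3 (0.15 log units; within the scatter), where two different groups gave no separation beyond the scatter. On that basis, no step beyond the scatter is expected in this assay, although the large steps argue for a wide range. The expected step, leaning slightly downward, is a 1.5-fold lower number from compound 3 to compound 4 (0.19 log units; within the scatter). For compound 4 the estimated value is 60000 nM, with an expected range from 15000 nM to 240000 nM.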

Compound 4, solubility: 45300 nM
Compound 4: middle estimate off by 1.3-fold (0.12 log units), on the high side; the range from low to high includes it.
By their numbers in this assay, from the lowest: compounds 4, 1 and 3 (each within the scatter of the next, the first and the last beyond it); then compound 2.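

In this assay, going by these compounds alone, 2,5-dioxopyrrolidin-1-yl in place of 4-((methoxycarbonyl)methyl)piperidin-1-yl gives a 2.0-fold lower number from compound 3 to compound 4 (0.31 log units; beyond the scatter), the first step at this place that does not involve the 4-methylpiperazin-1-yl group and still clears the scatter, although only modestly. The same entering group gives no such separation from the (2-cyanoethyl)(methyl)amino group, with a 1.4-fold lower number from compound 1 to compound 4 (0.15 log units; within the scatter), so the three lower compounds do not form one level: the two ends of that group can be told apart, while compound 1 cannot be told apart from either end. Within the data shown here, the remaining comparison, a 37-fold lower number from compound 2 to compound 4 (1.57 log units; beyond the scatter), shows that the large gap persists with a third, quite different group, and 4-methylpiperazin-1-yl remains the only one of the four groups at this place that stands far from the others.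

What sets that group apart stays open, as nothing shown accounts for any of these differences. The compounds shown also leave open where an unsubstituted piperazin-1-yl group or a morpholin-4-yl group on this saturated chain carbon would fall, nearer compound 2 or nearer the lower three.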